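Working notes on a small modulator series

The compounds below may be only part of what the source reports. "The series", "measured", "known", "first", "only" and "open" are said of these compounds alone.

Two compounds have numbers in a functional assay on CHO cells for positive allosteric modulation of metabotropic glutamate receptor 2 (Homo sapiens), read by scintillation counting and GTPgammaS binding, with a stated time of 30 min; a lower number here means that less compound is needed, a higher number that more compound is needed for the effect. Compound 1 `CCCn1ccc2c(NCc3ccccc3)cccc2c1=O` gives 2000 nM, and compound 2 `CCCn1ccc2c(NCc3ccc(OC)cc3)cccc2c1=O` gives 501 nM. Among the measured compounds shown here, the only measured step is a 4.0-fold lower number from compound 1 to compound 2 (0.60 log units; beyond the scatter), and compound 2 therefore stands lowest of the two numbers, with compound 1 as its nearest neighbour. Compound 3 `CCCn1ccc2c(NCc3ccccc3Cl)cccc2c1=O` has not been measured; it differs from compound 2 by 2-chlorophenyl in place of 4-methoxyphenyl on a saturated chain carbon bound to a nitrogen on an aromatic ring. For the measured compounds named here, the measured step bears on this change only in part: the methoxy of compound 2 brought a 4.0-fold lower number from compound 1 to compound 2 (0.60 log units; beyond the scatter) relative to compound 1, so removing it is expected to give back some or all of that gain, while the entering chlorine has no measured counterpart anywhere. On that basis compound 3 is expected to give 1500 nM in this assay, with a range from 500 nM to 4500 nM. The expected step is a 3.0-fold higher number from compound 2 to compound 3 (0.48 log units; beyond the scatter).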

Compound 3, half-maximal effective concentration: 200 nM
Compound 3: middle estimate off by 7.5-fold (0.88 log units), on the high side; measured number outside the range, below it.
By their numbers in this assay, from the lowest: compound 3; then compound 2; then compound 1.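

Replacing 4-methoxyphenyl with 2-chlorophenyl on a saturated chain carbon bound to a nitrogen on an aromatic ring gives a 2.5-fold lower number from compound 2 to compound 3 (0.40 log units; beyond the scatter) in this assay, so the methoxy is not required for a low number at this position. Chloro in place of hydrogen on an aromatic carbon gives a 10-fold lower number from compound 1 to compound 3 (1.00 log units; beyond the scatter), which shows that the unsubstituted phenyl of compound 1 can be improved by more than one kind of substituent, and by more than the methoxy achieved. No measured evidence explaining these differences is available.

The compounds shown do not separate the identity of the substituent from its place on the phenyl ring, since the chlorine and the methoxy differ in both. A 4-chlorophenyl or a 2-methoxyphenyl group at this position would bear directly on that question.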